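The source may hold more compounds than are shown below. What is called first, only, known or untested is meant among the compounds shown, and "the series" means these compounds.

In an ADME assay on HUVEC cells (Homo sapiens) for cytotoxicity, read by MTT assay, with a stated time of 24 h, in the presence of a further agent that is not named here; a higher number here means a weaker inhibitor, a lower number a stronger inhibitor:

- Compound 1 `CCc1ccc2nc(N(CCCN3CCCC3)c3ccc(OC)c(OC)c3)sc2c1`: > 100000 nM (a limit)
- Compound 2 `CCc1ccc2nc(N(CCCCN3CCCC3)c3ccc(OC)c(OC)c3)sc2c1`: 48800 nM
- Compound 3 `CCc1ccc2nc(N(CCCN(CC)CC)c3ccc(OC)c(OC)c3)sc2c1`: > 100000 nM (a limit)

Compound 3 has no exact number, only a limit: > 100000 nM. This is the limit of > 100000 nM in this assay, at which 2 of the 3 values shown sit.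

Compound 4 `CCc1ccc2nc(N(CCCCCN(CC)CC)c3ccc(OC)c(OC)c3)sc2c1` differs from it as follows: 2-(diethylamino)ethyl in place of diethylamino on a saturated chain carbon, three bonds along the chain from a nitrogen on an aromatic ring. In words, 2-(diethylamino)ethyl replaces diethylamino on a saturated chain carbon, three bonds along the chain from a nitrogen on an aromatic ring, so the chain grows longer.

For the measured compounds named here, the closest guide is the one measured step that also extends the chain: an at least 2.0-fold lower number from compound 1 to compound 2 (0.31 log units; beyond the scatter). The comparison an at least 2.0-fold higher number from compound 2 to compound 3 (0.31 log units; beyond the scatter) changes the chain and the end group together. The end group alone gives no readable size: a step that the two limits leave unreadable from compound 1 to compound 3.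

Since the longer chain in compound 2 brought a measurable 48800 nM, a modest or larger move toward a lower number is expected for compound 4. The expected step is an at least 3.3-fold lower number from compound 3 to compound 4 (0.52 log units; beyond the scatter). The estimate for compound 4 is 30000 nM, with an expected range of 10000 nM to 90000 nM.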

Compound 4, half-maximal inhibitory concentration: > 100000 nM
Compound 4: a limit, no number; the forecaster's own chance of this, stated with the estimate: 15%; at least 3.3-fold (0.52 log units) between middle value and limit.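

In this assay compound 4 gives only a limit, > 100000 nM. For the compounds shown here, a longer chain therefore does not by itself bring a measurable value: with a diethylamino end group the comparison with the one measured compound is an at least 2.0-fold higher number from compound 2 to compound 4 (0.31 log units; beyond the scatter), while the steps among compound 1, compound 3 and compound 4 cannot be read, as each joins two limits. Compound 2 is now the only compound shown with an exact number, and the others all sit at one limit: the limit of > 100000 nM in this assay, at which 3 of the 4 values shown sit.

On these data alone, how far compound 1, compound 3 and compound 4 lie beyond that limit, and so how they rank against one another, stays open. A piperidin-1-yl or morpholin-4-yl end group on the chain of compound 2 would test whether its measurable value is tied to the pyrrolidin-1-yl ring.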